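Removing a hydroxy group from a naphthyloxy acetohydrazone

A few compounds are considered here, and "the series" means these few. Any claim that something is new, unique, unknown or untested is made for them only; others in the source may bear on it.

Measured so far:
Compound 1, `O=C(COc1cccc2ccccc12)N/N=C/c1ccc([N+](=O)[O-])cc1`: 20 ug/mL
Compound 2, `O=C(COc1cccc2ccccc12)N/N=C/c1ccccc1O`: 20 ug/mL

Both compounds share the same core and were tested in an ADME assay on HEL cells (Homo sapiens) for cytotoxicity; on this read-out higher numbers stand for lower toxicity in this test and lower numbers for higher toxicity in this test. In this assay compound 1 gives 20 ug/mL, and compound 2 gives 20 ug/mL. Compound 2 therefore stands level with compound 1 at the digits shown, and the two values lie within the usual scatter of each other, so nothing can be said about an order between them.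

Compound 3, `O=C(COc1cccc2ccccc12)N/N=C/c1ccccc1`, has not yet been measured in this assay. It differs from compound 2 in one place: hydrogen in place of hydroxy on an aromatic carbon. Put another way, the hydroxy group on the six-membered aromatic ring of carbon only is gone, and a hydrogen sits there instead.

Within the data shown here, no step between measured compounds that differ in only one place is available, so there is no directly comparable change to lean on. The two measured values show no spread, and the change is small. The step expected for compound 3 is no change at the digits printed from compound 2 to compound 3 (within the scatter), that is, none beyond the scatter in either direction. Compound 3 is therefore estimated to give about 20 ug/mL in this assay, with a likely range from 10 ug/mL to 45 ug/mL.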

Compound 3, minimum cytotoxic concentration: 100 ug/mL
The estimate for compound 3 lay 5.0-fold (0.70 log units) below the measured number, and the stated range ends below it.
By their numbers in this assay, from the lowest: compounds 1 and 2 (each within the scatter of the next); then compound 3.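

In this assay the hydroxy group on this aromatic carbon proves to matter: replacing it with hydrogen gives a 5.0-fold higher number from compound 2 to compound 3 (0.70 log units; beyond the scatter) and so means lower toxicity in this test. Replacing nitro with hydrogen gives a 5.0-fold higher number from compound 1 to compound 3 (0.70 log units; beyond the scatter) and points the same way, so among these three compounds the plain phenyl stands apart, while the two compounds carrying a ring group remain within the scatter of each other. Nothing available explains this shift.

As far as these compounds go, with only hydroxy and nitro as ring groups, it remains open whether any group on this ring brings the number down or only certain ones do; a methoxy group, a chlorine atom or an amine on the same aromatic carbon would help to separate those two readings. From the compounds shown here alone, it is also open whether the higher number for the plain phenyl would hold with a different group elsewhere on the shared core, such as a methyl group on the carbon of the hydrazone link.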